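A few compounds are considered here, and "the series" means these few. Any claim that something is new, unique, unknown or untested is made for them only; others in the source may bear on it.

Compound 1 `CC(C)CCn1cnc2c(Nc3ccccc3)nc(N[C@H]3CC[C@H](N)CC3)nc21` gives in a functional assay on EOL1 cells (Homo sapiens) for inhibition, read by fluorescence, with a stated time of 72 h (a higher number here means a weaker inhibitor of growth, a lower number a stronger inhibitor of growth), a concentration for half-maximal growth inhibition of 10 nM, the lowest of the three numbers recorded. Compound 3 `N[C@H]1CC[C@H](Nc2nc(Nc3ccc(O)cc3)c3ncn(C4CCCCC4)c3n2)CC1` gives 220 nM in this assay, and compound 2 `CCCCCCn1cnc2c(Nc3ccc(Cl)cc3)nc(N[C@H]3CC[C@H](N)CC3)nc21` gives 440 nM; both gaps to compound 1 lie beyond the scatter, but each of these compounds differs from compound 1 in several places at once, so neither tells what a single change does. Compound 4 `CC(C)CCn1cnc2c(Nc3cccc(Cl)c3)nc(N[C@H]3CC[C@H](N)CC3)nc21` carries one change relative to compound 1: chloro in place of hydrogen on an aromatic carbon. For the measured compounds named here, no single-place step between measured compounds exists to guide the expectation. The step of a 1.5-fold higher number from compound 1 to compound 4 (0.18 log units; within the scatter) is expected to be small, at most a slight weakening, and not clearly beyond the scatter. Compound 4 is therefore estimated at 15 nM, within a range from 5 nM to 50 nM.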

Compound 4, concentration for 50% growth inhibition: 60 nM
For compound 4 the middle estimate is 4.0-fold (0.60 log units) below the measured one; measured number above the stated range.
By their numbers in this assay, from the lowest: compound 1; then compound 4; then compounds 3 and 2 (each within the scatter of the next).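

In this assay the change from phenyl to 3-chlorophenyl gives the first single-place step available here, a 6.0-fold higher number from compound 1 to compound 4 (0.78 log units; beyond the scatter). It shows that one chloro on this aromatic ring, meta to a large group, is enough to weaken growth inhibition by more than the scatter. No measurement shown gives a reason for this step.

The compounds shown leave open whether a fluoro, a methoxy or an amine in this same place would give a step of similar size. They also leave open whether chloro would cost as much at another carbon of this ring.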